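The source may hold more compounds than are shown below. What is called first, only, known or untested is meant among the compounds shown, and "the series" means these compounds.

Three compounds share one core and differ only in the group on an aromatic carbon between two ring nitrogen atoms. In a functional assay on ileum for antagonist activity at Substance-P receptor (Cavia porcellus) (on this read-out higher numbers stand for weaker inhibition and lower numbers for stronger inhibition), compound 1 `Cc1ccccc1-c1ncnc2c1C(=O)N(Cc1cc(C(F)(F)F)cc(C(F)(F)F)c1)C[C@@H](C)CO2` gives 162 nM. Compound 2 `Cc1ccccc1-c1nc(N(C)C)nc2c1C(=O)N(Cc1cc(C(F)(F)F)cc(C(F)(F)F)c1)C[C@@H](C)CO2`, with dimethylamino in that place, gives 52.9 nM. Compound 3 `CC(=O)N1CCN(c2nc3c(c(-c4ccccc4C)n2)C(=O)N(Cc2cc(C(F)(F)F)cc(C(F)(F)F)c2)C[C@@H](C)CO3)CC1`, carrying 4-acetylpiperazin-1-yl in that place, gives 0.345 nM. This is the lowest number of the three, so compound 3 is the strongest inhibitor shown: a 470-fold lower number from compound 1 to compound 3 (2.67 log units; beyond the scatter) and a 150-fold lower number from compound 2 to compound 3 (2.19 log units; beyond the scatter), while a 3.1-fold lower number from compound 1 to compound 2 (0.49 log units; beyond the scatter). Compound 4 `CC(=O)N1C(C)CN(c2nc3c(c(-c4ccccc4C)n2)C(=O)N(Cc2cc(C(F)(F)F)cc(C(F)(F)F)c2)C[C@@H](C)CO3)CC1C` is not yet measured. It differs from compound 3 by a group of 11 heavy atoms (8 carbon, 2 nitrogen, 1 oxygen; one six-membered non-aromatic ring with 2 hetero atoms) in place of a group of 9 heavy atoms (6 carbon, 2 nitrogen, 1 oxygen; one six-membered non-aromatic ring with 2 hetero atoms), on an aromatic carbon; the entering group has no common name. Among the measured compounds shown here, no measured step tests this kind of change. The measured steps each swapped one group for a quite different one at this carbon and moved the numbers widely, which shows only that this position is sensitive, not how a larger version of the same ring will behave. For compound 4 a small shift is expected in this assay, a 2.0-fold higher number from compound 3 to compound 4 (0.31 log units; beyond the scatter). The estimate for compound 4 in this assay is 0.7 nM, within 0.15 nM to 3.5 nM.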

Compound 4, antagonist equilibrium constant: 52.9 nM
For compound 4 the middle estimate is 76-fold (1.88 log units) below the measured one, and the stated range ends below it.
By their numbers in this assay, from the lowest: compound 3; then compounds 2 and 4 (each within the scatter of the next); then compound 1.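

The entering group keeps the ring type and the hydrogen-bond counts of 4-acetylpiperazin-1-yl and differs from it by extra carbon atoms, yet in this assay this costs a large step, a 150-fold higher number from compound 3 to compound 4 (2.19 log units; beyond the scatter), so a ring of this kind does not by itself bring the strong inhibition of compound 3. Compound 4 keeps only a modest gain over the bare position, a 3.1-fold lower number from compound 1 to compound 4 (0.49 log units; beyond the scatter), and it gains nothing over the much smaller dimethylamino group, with no change at the digits printed from compound 2 to compound 4 (within the scatter). No measurement here accounts for this sensitivity to so small a change.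

Open, going by these compounds, is whether a single methyl group on the ring of 4-acetylpiperazin-1-yl would cost as much as the full change does. Also open, on these data alone, is how much the acetyl group contributes, which a plain piperazin-1-yl or a morpholin-4-yl group could test.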